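Moving the Methoxy Group on the Pendant Phenyl Ring

The source may report more compounds than this note shows. Statements on the series, on what has been measured and on what is new or still open speak of the compounds shown alone.

Compound 1 `COc1ccccc1-c1ccc2ncn(-c3cc(OC)c(OC)c(OC)c3)c2c1` gives 4320 nM in a functional assay on A549 cells (Homo sapiens) for antiproliferative activity, read by MTT assay, with a stated time of 72 h; on this read-out higher numbers stand for weaker inhibition and lower numbers for stronger inhibition.
Compound 2 `COc1cc(-n2cnc3ccc(-c4ccccc4Cl)cc32)cc(OC)c1OC` reaches only the limit of this assay, > 10000 nM.
Compound 3 `COc1cc(-n2cnc3ccc(-c4ccc(C)cc4F)cc32)cc(OC)c1OC` likewise stops at the limit, > 10000 nM.

Going by the values given here, compound 1 thus stands as the only compound of the three with a number in this assay; the other two values are limits. Both measured steps leave from compound 1: an at least 2.3-fold higher number from compound 1 to compound 2 (0.36 log units; beyond the scatter), and an at least 2.3-fold higher number from compound 1 to compound 3 (0.36 log units; beyond the scatter). The step between the two limits, a step that the two limits leave unreadable from compound 2 to compound 3, tells nothing about size. Both readable steps therefore point the same way, with the limit of > 10000 nM in this assay, at which 2 of the 3 values shown sit, setting the boundary at which compound 2 and compound 3 sit.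

Compound 4 `COc1ccc(-c2ccc3ncn(-c4cc(OC)c(OC)c(OC)c4)c3c2)cc1` differs from compound 1 by 4-methoxyphenyl in place of 2-methoxyphenyl on an aromatic carbon. The change keeps the methoxy group on the pendant ring and moves it, whereas the measured steps exchanged that group for other substituents. A weakening is expected, but smaller than in those steps, so compound 4 is estimated at 6000 nM, between 2500 nM and 14000 nM, a step of a 1.4-fold higher number from compound 1 to compound 4 (0.14 log units; within the scatter).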

Compound 4, half-maximal inhibitory concentration: > 10000 nM
Compound 4: only a limit was reported; the forecaster's own chance of this, stated with the estimate: 25%; middle value at least 1.6-fold (0.22 log units) from the limit.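

The earlier steps shown here exchanged the methoxy group on the pendant ring for other substituents. This change keeps the same atoms and only moves the group, from 2-methoxyphenyl to 4-methoxyphenyl, yet it still gives an at least 2.3-fold higher number from compound 1 to compound 4 (0.36 log units; beyond the scatter) in this assay, so the place of the methoxy group matters as well as its presence. The value of compound 4 is a limit, so this step has no upper end, and the steps from compound 2 and compound 3 to compound 4 cannot be read. Of the pendant groups shown, only the 2-methoxyphenyl of compound 1 gives a number, and the rest share one boundary: the limit of > 10000 nM in this assay, at which 3 of the 4 values shown sit.

From the compounds shown here alone, whether a hydroxyl or an amine in place of the methoxy group of compound 1 would give a number in this assay stays open. Going by these compounds, how far compound 2, compound 3 and compound 4 differ from one another also stays open.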